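Replacing 4-(Trifluoromethyl)pyridin-3-yl with Phenyl in Compound 4

The source may report more compounds than this note shows. Statements on the series, on what has been measured and on what is new or still open speak of the compounds shown alone.

Of the compounds shown here, three sharing a core have been measured in a physicochemical assay for solubility, using the shake flask method, with a stated time of 24 h, at pH 6.8; on this read-out higher numbers stand for higher solubility and lower numbers for lower solubility. Compound 1 (`O=c1ncn(CC2CCCC2)c2ccc(Oc3ncccc3C(F)(F)F)cc12`) gives 3.3 ug/mL, compound 2 (`O=c1ncn(Cc2ccc(F)cc2F)c2cc(F)c(Oc3ncccc3C(F)(F)F)cc12`) gives 18 ug/mL, and compound 3 (`O=c1ncn(Cc2c(F)cc(F)cc2F)c2ccc(Oc3cnccc3C(F)(F)F)cc12`) gives 4.6 ug/mL. Compound 3 stands within the usual scatter of compound 1, while compound 2 lies beyond that scatter on the higher side of compound 3.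

The next structure, compound 4 (`O=c1ncn(Cc2c(F)cc(F)cc2F)c2ccc(Oc3ccccc3)cc12`), has phenyl in place of 4-(trifluoromethyl)pyridin-3-yl on an oxygen on an aromatic ring. Among the compounds with values here, no two measured compounds differ in one place only, and none of them carries phenyl on that oxygen, so the data give no direct measure of this change. The expectation therefore starts from compound 3 at 4.6 ug/mL and takes in compound 1 at 3.3 ug/mL, with compound 2 at 18 ug/mL as a reminder that values in this small set can lie further apart. A small downward move is expected in this assay, and the estimated 1.4-fold lower number from compound 3 to compound 4 (0.16 log units; within the scatter) is not expected to pass beyond the scatter. The range is kept wide for that lack of direct evidence. For compound 4 the estimate is 3.2 ug/mL, with a range of 0.9 ug/mL to 11 ug/mL.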

Compound 4, solubility: 4.6 ug/mL
Compound 4: the middle estimate sits 1.4-fold (0.16 log units) below what was measured, and the stated range covers the measured number.
By their numbers in this assay, from the lowest: compounds 1, 3 and 4 (each within the scatter of the next); then compound 2.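

Within the data shown here, the step from compound 3 gives the first direct reading at this position, on an oxygen on an aromatic ring whose other neighbours are aromatic carbon: in this assay, phenyl in place of 4-(trifluoromethyl)pyridin-3-yl gives no change at the digits printed from compound 3 to compound 4 (within the scatter). Among these compounds, on this core, then, a group of carbon only can stand where a larger group with a ring nitrogen, a trifluoromethyl and a hydrogen-bond acceptor stood, and the read-out stays within the scatter, even though the single step removes the ring nitrogen and the trifluoromethyl together. No measurement of any other property bears on this result, and the step by itself does not explain it.

The compounds shown leave open whether the ring nitrogen or the trifluoromethyl alone would leave the number as flat, and whether the same exchange would read alike on the other groups that compound 1 and compound 2 carry on the shared core. They also leave open how this assay would respond to a phenyl bearing an amine or a carboxylic acid on this oxygen.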